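The source may hold more compounds than are shown below. What is called first, only, known or untested is meant among the compounds shown, and "the series" means these compounds.

Of the compounds shown here, three sharing one core have been measured in a physicochemical assay for lipophilicity; on this read-out higher numbers stand for higher lipophilicity and lower numbers for lower lipophilicity. Compound 1 (`CCn1cnc2c(-c3ccc(F)c(Oc4ccnc(C)c4)c3)cnnc21`) gives 2.6 in this test, and compound 2 (`CCn1cnc2c(-c3ccc(F)c(-c4ccc(S(C)(=O)=O)cc4OC)c3)cnnc21`) gives 2.5 in the same test. These two numbers lie within the scatter of each other, so the read-out does not separate compound 2 from compound 1. Compound 3 (`CCn1cnc2c(-c3ccc(F)c(-c4ccc(S(=O)(=O)CC)cc4Cl)c3)cnnc21`) gives 3.2 on the same scale, which puts it higher than compound 2 and beyond the scatter. Within the data shown here, no two of these three compounds differ in only one place, so no measured step is available to size a change on the sulfonyl group.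

Compound 4 (`CCn1cnc2c(-c3ccc(F)c(-c4ccc(S(=O)(=O)C5COC5)cc4OC)c3)cnnc21`) has not yet been measured. It differs from compound 2 in a single place (oxetan-3-yl in place of methyl on a sulfonyl sulfur), with oxetan-3-yl in place of methyl on a sulfonyl sulfur. In this assay, among the measured compounds shown here, a small upward step is expected, one that may well stay within the scatter, and the only anchor is the value of compound 2 (2.5). The estimate for this change is a modest rise (a number 0.20 log units higher from compound 2 to compound 4 (within the scatter)) and no more than that. Compound 4 is therefore estimated at 2.7 in a range expected to run from 2.3 to 3.1 on this scale.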

Compound 4, distribution coefficient: 2.2
For compound 4 the middle estimate is 0.50 log units above the measured one, and the stated range ends above it.
By their numbers in this assay, from the lowest: compounds 4, 2 and 1 (each within the scatter of the next, the first and the last beyond it); then compound 3.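

Among these compounds, this pair gives the first measured step at a sulfonyl sulfur whose other neighbour is an aromatic carbon: in this assay, putting oxetan-3-yl in place of methyl gives (a number 0.30 log units lower from compound 2 to compound 4 (within the scatter)). The read-out therefore does not separate the two compounds, even though the entering group brings 4 heavy atoms where the leaving methyl had 1, along with a four-membered non-aromatic ring and 1 hydrogen-bond acceptor. Nothing shown explains the size of this step, and no supporting evidence bears on it.

With a single step at this place, the compounds shown do not establish how a different group on the sulfonyl sulfur, such as an amine, a carboxylic acid or a longer chain, would read in this assay when set against methyl or oxetan-3-yl. They also leave open whether the exchange of methyl for oxetan-3-yl would stay within the scatter on a compound that differs from compound 2 elsewhere, since this one pair cannot show whether the step carries over.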